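The compounds below may be only part of what the source reports. "The series", "measured", "known", "first", "only" and "open" are said of these compounds alone.

Working notes on the series.

Compound 1 `COc1ccc2c(c1)CC/C(=C\c1ccccc1C)C2=O` carries a methyl on the outer six-membered aromatic ring and an exocyclic double bond linking that ring to the shared core. In an assay on CHO cells for inhibition of 1,25-dihydroxyvitamin D(3) 24-hydroxylase, mitochondrial (Homo sapiens) (a lower number here means a stronger inhibitor, a higher number a weaker inhibitor), compound 1 gives 480000 nM, the highest of the two numbers recorded so far. Compound 2 `COc1ccc2c(c1)CCC(Cc1ccccc1Br)C2=O` has a bromo on the outer ring and a saturated link to the core; in this assay compound 2 gives 16300 nM, a value well beyond the scatter from that of compound 1. Going by the values given here, the two compounds differ in more than one place, so these two numbers are only set side by side here and no single step is drawn between them.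

Compound 3 `COc1ccc2c(c1)CC/C(=C\c1ccccc1Br)C2=O` is the next member: relative to compound 1 the change is bromo in place of methyl on an aromatic carbon, with the exocyclic double bond kept. Among the compounds with values here, no step between measured compounds matches this change. In this assay compound 3 is expected to sit lower than compound 1, by a step of about a 4.8-fold lower number from compound 1 to compound 3 (0.68 log units; beyond the scatter), because compound 2 with 16300 nM shows that a bromo-bearing analogue in this series can reach a markedly lower number, though its saturated link leaves the size of the step uncertain. The estimated value for compound 3 is 100000 nM, with a range from 20000 nM to 480000 nM.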

Compound 3, half-maximal inhibitory concentration: 122000 nM
For compound 3 the middle estimate is 1.2-fold (0.09 log units) below the measured one, within the range that was stated.
By their numbers in this assay, from the lowest: compound 2; then compound 3; then compound 1.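

Going by these compounds alone, the swap of methyl for bromo on an aromatic carbon, ortho to a large group, gives the first reading of this position with the rest of the molecule held fixed: in this assay it is a 3.9-fold lower number from compound 1 to compound 3 (0.59 log units; beyond the scatter), a modest step that shows this single substituent moves the number. It accounts for only part of the earlier gap, as with bromo on both compounds and only the link to the core differing, compound 3 gives 122000 nM while compound 2 gives 16300 nM. No measurement on hand speaks to the reason for the step from methyl to bromo.

The compounds shown leave open how a chloro, a methoxy, an amine or a carboxylic acid would read at this same place on the outer ring. They also leave open whether the step from methyl to bromo keeps its size on the saturated link, as the methyl partner of compound 2 is not among them.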